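Swapping the Thiazole Attachment in a Clearance Series

This account rests on a few compounds, and the source may have more. Where it says the series, first, only, none or still open, it means among the compounds named here.

Compound 1 `O=C(COCc1cccnc1)N1CCN(c2ccc(Cl)cc2Cl)CC1` gives 210 mL.min-1.g-1
Compound 2 `O=C(COCc1ncccn1)N1CCN(c2ccc(Cl)cc2Cl)CC1` gives 16 mL.min-1.g-1
Compound 3 `O=C(COCc1cscn1)N1CCN(c2ccc(Cl)cc2Cl)CC1` gives 62 mL.min-1.g-1

All three values come from an in vitro ADME assay on microsomes from liver (Homo sapiens) for metabolic stability; on this read-out higher numbers stand for fast clearance and lower numbers for slow clearance. Compound 3 stands second highest of the three, with compound 1 higher and compound 2 lower. Compound 4 `O=C(COCc1nccs1)N1CCN(c2ccc(Cl)cc2Cl)CC1` differs from compound 3 by 1,3-thiazol-2-yl in place of 1,3-thiazol-4-yl on a saturated chain carbon bound to an oxygen on a saturated carbon. Exchanging the ring has already moved the numbers: a 13-fold lower number from compound 1 to compound 2 (1.12 log units; beyond the scatter) was large, while a 3.4-fold lower number from compound 1 to compound 3 (0.53 log units; beyond the scatter) and a 3.9-fold higher number from compound 2 to compound 3 (0.59 log units; beyond the scatter) were modest. None of these steps keeps the same ring, so they bear on this change only indirectly. Compound 2, which carries pyrimidin-2-yl, gives 16 mL.min-1.g-1, so a slight fall in this assay is expected, though perhaps none beyond the scatter. The estimated change is a 1.6-fold lower number from compound 3 to compound 4 (0.19 log units; within the scatter). For compound 4 the estimated value is 40 mL.min-1.g-1, within a range of 15 mL.min-1.g-1 to 110 mL.min-1.g-1.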

Compound 4, intrinsic clearance in microsomes: 80 mL.min-1.g-1
Compound 4: middle estimate off by 2.0-fold (0.30 log units), on the low side; measured number inside the range.
By their numbers in this assay, from the lowest: compound 2; then compounds 3 and 4 (each within the scatter of the next); then compound 1.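

The two thiazole attachments cannot be told apart in this assay, with a 1.3-fold higher number from compound 3 to compound 4 (0.11 log units; within the scatter). The choice of ring still matters at this place, since 1,3-thiazol-2-yl stands apart from pyrimidin-2-yl, with a 5.0-fold higher number from compound 2 to compound 4 (0.70 log units; beyond the scatter), and from pyridin-3-yl, with a 2.6-fold lower number from compound 1 to compound 4 (0.42 log units; beyond the scatter). Nothing given here accounts for these differences. From the compounds shown here alone, it remains open whether 1,3-thiazol-5-yl would match the other two thiazole attachments on a saturated chain carbon bound to an oxygen on a saturated carbon. Going by these compounds, it is also open where a 1,3-oxazol-2-yl group would fall.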